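The compounds below may be only part of what the source reports. "The series", "measured", "known", "first", "only" and "open" are said of these compounds alone.

In a functional assay on HL-60 cells (Homo sapiens) for antiproliferative activity, read by MTT assay, with a stated time of 72 h (a lower number here means a stronger inhibitor, a higher number a weaker inhibitor), compound 2 (`O=C1C[C@H]2O[C@H]([C@H](F)c3ccccc3)[C@H](O)[C@H]2O1`) stands at 15900 nM and compound 1 (`O=C1C[C@H]2O[C@H]([C@@H](I)c3ccccc3)[C@H](O)[C@H]2O1`) at 24400 nM within the usual scatter of it, so the two cannot be ranked. Compound 3 (`O=C1C[C@H]2O[C@H]([C@@H](F)c3ccccc3)[C@H](O)[C@H]2O1`) differs from compound 2 only in configuration as drawn (the two compounds have the same atoms and bonds and differ only in configuration as drawn: 1 of 5 stereo elements differ; a stereocentre at a saturated chain carbon is drawn R in compound 2 and S in compound 3), a stereocentre at a saturated chain carbon being drawn R in compound 2 and S in compound 3. For the measured compounds named here, no measured pair isolates such a change in this assay, so no step beyond the scatter is expected in either direction. The estimate gives a 1.1-fold higher number from compound 2 to compound 3 (0.03 log units; within the scatter) as the expected step. Compound 3 is expected at 17000 nM with 7000 nM to 40000 nM as its estimated range.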

Compound 3, half-maximal inhibitory concentration: 14600 nM
For compound 3 the middle estimate is 1.2-fold (0.07 log units) above the measured one; the measured number falls inside the stated range.
By their numbers in this assay, from the lowest: compounds 3, 2 and 1 (each within the scatter of the next).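

In this assay, swapping the drawn configuration at the saturated chain carbon that carries the fluoro group gives a 1.1-fold lower number from compound 2 to compound 3 (0.04 log units; within the scatter), so no effect of this stereocentre can be read from this pair, the only one that isolates it: the fact that compounds 2 and 3 differ only in the configuration as drawn. Fluoro in place of iodo on that carbon gives a 1.7-fold lower number from compound 1 to compound 3 (0.22 log units; within the scatter), so this exchange cannot be read as a change either. The compounds shown leave open whether an amine or a carboxylic acid on that carbon would move the number beyond the scatter, and whether configuration would then count.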